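The compounds below may be only part of what the source reports. "The series", "measured", "known", "first", "only" and "open" are said of these compounds alone.

Compound 1, `CNC(=O)c1cc(C(=O)NC2CC2)cn([C@H](C)c2ccccc2)c1=O`, gives 3.4 in a physicochemical assay for lipophilicity, at pH 7.4; on this read-out higher numbers stand for higher lipophilicity and lower numbers for lower lipophilicity. Compound 2, `CNC(=O)c1cc(C(=O)NC2CC2)cn(Cc2cccc(C)c2)c1=O`, gives 3.6 in this assay. Going by the values given here, the only step between measured compounds, a number 0.20 log units higher from compound 1 to compound 2 (within the scatter), stays within the scatter. Compound 2 thus carries the highest of the two numbers, yet its nearest neighbour, compound 1, sits within the scatter of it, so no order between the two can be claimed.

Compound 3, `CNC(=O)c1cc(C(=O)NC2CC2)cn(Cc2cccc(C#N)c2)c1=O`, differs from compound 2 in one place: cyano in place of methyl on an aromatic carbon. Among the compounds with values here, no measured step covers a change of this kind. Within the data shown here, the one step recorded concerns the group on the aromatic nitrogen, not a group on the aromatic carbon, and it was small, so it gives no direct guide to what compound 3 will show. Resting on the structural change alone, a step of a number 0.90 log units lower from compound 2 to compound 3 (beyond the scatter) is expected in this assay from compound 2 to compound 3. Compound 3 is accordingly estimated at 2.7 in this assay, with a range from 2.2 to 3.2.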

Compound 3, distribution coefficient: 2.6
The estimate for compound 3 lay 0.10 log units above the measured number, and the stated range covers the measured number.
By their numbers in this assay, from the lowest: compound 3; then compounds 1 and 2 (each within the scatter of the next).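

Cyano in place of methyl on an aromatic carbon gives a number 1.00 log units lower from compound 2 to compound 3 (beyond the scatter) in this assay, the only step shown that lies beyond the scatter. The earlier pair, which differed in the group on the aromatic nitrogen, gave a number 0.20 log units higher from compound 1 to compound 2 (within the scatter) and so allowed no order, whereas this position, on the six-membered aromatic ring of carbon only, is where a single change is seen to move the number. The change replaces one heavy atom with two and adds a hydrogen-bond acceptor, with no donor and no net charge, but a single pair cannot separate these features from one another. Nothing at hand accounts for the size of this step.

On these data alone, it remains open whether an amine, a carboxylic acid or a methoxy group on the same aromatic carbon would give a step of similar size, or one in the other direction. As far as these compounds go, it also remains open whether cyano would give a comparable step elsewhere on this ring, or with a 1-phenylethyl group on the aromatic nitrogen in place of the benzyl group.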